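The compounds below may be only part of what the source reports. "The series", "measured", "known", "first", "only" and "open" are said of these compounds alone.

Measured so far:
Compound 1 `CS(=O)(=O)Nc1ccc2c(c1)S(=O)(=O)N=C(C1=C(O)C3CCCC3N(Cc3ccc(F)cn3)C1=O)N2` gives > 1 h in an in vitro ADME assay on microsomes from liver (Homo sapiens) for metabolic stability (a higher number here means that the compound lasts longer, a lower number that the compound disappears faster), which is a limit of the assay and not a number.
Compound 2 `CS(=O)(=O)Nc1ccc2c(c1)S(=O)(=O)N=C(C1=C(O)[C@H]3CCC[C@H]3N(Cc3ccc(F)c(Cl)c3)C1=O)N2` gives > 1 h in this assay, again a limit of the assay.
Compound 3 `CC(C)(C)CCN1C(=O)C(C2=NS(=O)(=O)c3cc(NS(C)(=O)=O)ccc3N2)=C(O)C2CCCCCC21` gives 0.45 h in this assay.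

Compound 1 therefore stands at the limit of > 1 h in this assay, at which 2 of the 3 values shown sit, so its true half-life is not known beyond that boundary. Compound 3 is the only one of the three with a definite number in this assay.

Compound 4 `CS(=O)(=O)Nc1ccc2c(c1)S(=O)(=O)N=C(C1=C(O)C3CCCC3N(Cc3ccccc3)C1=O)N2` has not yet been measured. It differs from compound 1 in one place: phenyl in place of 5-fluoropyridin-2-yl on a saturated chain carbon bound to an amide-type nitrogen in a ring. Among the compounds with values here, no pair of measured compounds shows this exchange, so no measured step sets its size. With compound 1 sitting at the limit of this assay, any drop would have to be sizeable before a number appears; a step from compound 1 to compound 4 of about an at least 1.2-fold lower number from compound 1 to compound 4 (0.09 log units; that floor lies within the scatter) is expected here, near the edge of the usual scatter. Compound 4 is thus expected to reach 0.8 h in this assay, within a range of 0.4 h to 1.6 h.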

Compound 4, half-life: 0.833 h
Compound 4: the middle estimate sits 1.0-fold (0.02 log units) below what was measured; the range from low to high includes it.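

In this assay compound 1 gives > 1 h, which is a limit of the assay and not a number. Phenyl in place of 5-fluoropyridin-2-yl gives this position its first step on the core of compound 1, an at least 1.2-fold lower number from compound 1 to compound 4 (0.07 log units; that floor lies within the scatter), so the exchange is not shown to make a real difference. The full size of the step cannot be read because compound 1 gives only a boundary: the limit of > 1 h in this assay, at which 2 of the 4 values shown sit.

The compounds shown leave open whether the ring nitrogen or the fluorine of the group that leaves accounts for any difference, which a fluorophenyl or an unsubstituted pyridinyl group could separate. They also leave open how this assay would read with an amine or a carboxylic acid on the phenyl of compound 4.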